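The source may hold more compounds than are shown below. What is called first, only, known or untested is meant among the compounds shown, and "the series" means these compounds.

Compound 2 `O=C1CS/C(=N\c2csc(-c3ccccc3)c2)N1` and compound 1 `Cc1ccc(-c2cc(/N=C3/NC(=O)CS3)cs2)cc1` share a core that carries a bare phenyl; compound 1 adds a methyl to it. In a functional assay on HT-29 cells (Homo sapiens) for cytotoxicity, read by MTT assay, with a stated time of 72 h (a lower number here means a stronger inhibitor, a higher number a weaker inhibitor), compound 2 gives a value that is a limit of the measurement, > 50000 nM. Compound 1 likewise gives only a limit, > 50000 nM. The step that the two limits leave unreadable from compound 2 to compound 1 is therefore methyl in place of hydrogen on an aromatic carbon whose size cannot be read, because of the limit of > 50000 nM in this assay, at which 2 of the 3 values shown sit.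

Among the compounds with values here, compound 3 `O=C1CS/C(=N\c2csc(-c3ccc(Cl)cc3)c2)N1c1ccccc1` gives the one real number, 41400 nM; how its core differs from that of compound 2 is not broken down here.

Compound 4 `Cc1ccc(N2C(=O)CS/C2=N\c2csc(-c3ccc(Cl)cc3)c2)cc1` makes the same change, (methyl in place of hydrogen on an aromatic carbon). Within the data shown here, compound 4 is expected to give about 35000 nM, with an estimated step of a 1.2-fold lower number from compound 3 to compound 4 (0.07 log units; within the scatter) and a range from 12000 nM to 100000 nM, since the only measured pair with this change, compound 2 to compound 1, gives no readable size.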

Compound 4, half-maximal inhibitory concentration: 28900 nM
Compound 4: middle estimate off by 1.2-fold (0.08 log units), on the high side, and the stated range covers the measured number.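

In this assay, the change from phenyl to 4-methylphenyl gives a 1.4-fold lower number from compound 3 to compound 4 (0.16 log units; within the scatter), so on this core the added methyl does nothing that can be told apart from the normal spread of repeat measurements. The same kind of change on the other core, in the pair compound 2 and compound 1, cannot be read because both compounds sit at a limit of the assay: the limit of > 50000 nM in this assay, at which 2 of the 4 values shown sit. This single readable step therefore does not show that the methyl acts alike on both cores.

Still open, going by these compounds, is whether an amine, a carboxylic acid or a longer chain in place of the methyl would move the number beyond the scatter. Also open, on these data alone, is how the methyl would read on a core whose values lie clear of the limit.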